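Methyl addition on a biaryl amide acid series

The source may report more compounds than this note shows. Statements on the series, on what has been measured and on what is new or still open speak of the compounds shown alone.

Working notes on three measured compounds and one open one. Compound 1 `O=C(O)c1cccc(NC(=O)c2cccc(OCc3ccccc3)c2)c1` carries a benzyloxy group on its aryl amide; in an assay on isolated protein for agonist activity at Bile acid receptor (Homo sapiens), read by TR-FRET, with a stated time of 3 h, in the absence of a further agent (a lower number here means that less compound is needed, a higher number that more compound is needed for the effect), compound 1 gives 1160 nM. Compound 2 `Cc1cccc(COc2cccc(C(=O)Nc3cccc(C(=O)O)c3)c2)c1` differs from compound 1 by methyl in place of hydrogen on an aromatic carbon and compound 2 gives 1860 nM; the step is a 1.6-fold higher number from compound 1 to compound 2 (0.21 log units; within the scatter). Compound 3 `O=C(O)c1cccc(NC(=O)c2cccc(-c3ccccc3)c2)c1` differs from compound 1 by phenyl in place of benzyloxy on an aromatic carbon, and compound 3 gives 25 nM, a step of a 46-fold lower number from compound 1 to compound 3 (1.67 log units; beyond the scatter). Against compound 2 the step is a 74-fold lower number from compound 2 to compound 3 (1.87 log units; beyond the scatter), so compound 3 stands lowest of the three, both gaps beyond the scatter.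

Compound 4 `Cc1ccccc1-c1cccc(C(=O)Nc2cccc(C(=O)O)c2)c1` has not yet been measured. It differs from compound 3 by methyl in place of hydrogen on an aromatic carbon. This is the same kind of change as that between compound 1 and compound 2, not the same: in that pair the methyl enters meta to a large group, here it enters ortho to a large group, and the cores differ as described above. Because a 1.6-fold higher number from compound 1 to compound 2 (0.21 log units; within the scatter) stayed within the scatter, the step expected here is a 1.6-fold higher number from compound 3 to compound 4 (0.20 log units; within the scatter). Compound 4 is therefore estimated at 40 nM, with the likely range from 15 nM to 120 nM.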

Compound 4, half-maximal effective concentration: 68 nM
For compound 4 the middle estimate is 1.7-fold (0.23 log units) below the measured one; the measured number falls inside the stated range.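

In this assay, methyl in place of hydrogen on the core of compound 3, ortho to a large group, gives a 2.7-fold higher number from compound 3 to compound 4 (0.43 log units; beyond the scatter), and the gap to the same change on the core of compound 1 cannot be told from scatter: the same change on two cores in this assay, a 1.6-fold higher number (0.21 log units; within the scatter) from compound 1 to compound 2 and a 2.7-fold higher number (0.43 log units; beyond the scatter) from compound 3 to compound 4, 1.7-fold (0.23 log units) apart, within the scatter of two such steps With the methyl in place, the phenyl-type group still stands well clear of both benzyloxy-type compounds, with a 17-fold lower number from compound 1 to compound 4 (1.23 log units; beyond the scatter) and a 27-fold lower number from compound 2 to compound 4 (1.44 log units; beyond the scatter). Among the compounds shown here, this is only one pair of cores, however, and the methyl stands at a different place on each, so the data neither separate the effect of place from that of core nor establish a rule for the series, and only the step on the core of compound 3 lies beyond the scatter.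

On these data alone, a methyl elsewhere on the phenyl ring of compound 3 remains open, as does a chlorine atom or a methoxy group in the place of the 2-methyl group. Whether either follows the methyl step on both cores also stays unanswered.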